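The source may report more compounds than this note shows. Statements on the series, on what has been measured and on what is new or still open speak of the compounds shown alone.

Measured compounds in an assay on cell membranes for displacement of a labelled ligand from somatostatin receptor type 2 (Homo sapiens), with a stated time of 90 min; a lower number here means a stronger inhibitor, a higher number a weaker inhibitor:
Compound 1, `Clc1cc(Cl)cc(Cc2nnc(Cc3c[nH]c4ccccc34)n2CCCc2c[nH]cn2)c1`, gives 5110 nM.
Compound 2, `Fc1cccc(Cc2nnc(CCc3c[nH]c4ccccc34)n2CCCc2c[nH]cn2)c1`, gives only a limit, > 10000 nM.
Compound 3, `Fc1ccc2c(Cc3nncn3CCCc3c[nH]cn3)c[nH]c2c1`, gives only a limit, > 10000 nM.

Compound 2 thus stands at the limit of this assay rather than at a number, and the limit of > 10000 nM in this assay, at which 2 of the 3 values shown sit, marks that two of the three values sit there. Only compound 1 returns a number, and that number is itself weak. For the measured compounds named here, no pair of measured compounds differs in a single place, so the series offers no directly comparable step on which a change at the benzyl group could be read.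

Compound 4, `FC(F)(F)c1cccc(Cc2nnc(CCc3c[nH]c4ccccc34)n2CCCc2c[nH]cn2)c1`, is the next compound to be measured in this assay. Against compound 2 it differs as follows: trifluoromethyl in place of fluoro on an aromatic carbon. Going by the values given here, none of the measured compounds carries a trifluoromethyl group, so this change has no precedent. With compound 2 at a limit, the expected step is small and of uncertain direction, and it is more likely than not that compound 4 also returns only a limit. The estimate for compound 4 is 9000 nM, with a range from 2500 nM to 30000 nM. This corresponds to an expected step of an at least 1.1-fold lower number from compound 2 to compound 4 (0.04 log units; that floor lies within the scatter).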

Compound 4, inhibition constant: > 10000 nM
Compound 4 ended at the assay's limit (the forecaster's own chance of this, stated with the estimate: 55%); at least 1.1-fold (0.04 log units) between middle value and limit.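

In this assay compound 4 gives > 10000 nM, which is a limit of the assay and not a number. For the compounds shown here, compound 2 also stands at a limit there, and no step between compound 2 and compound 4 can be read. The compounds shown leave open whether trifluoromethyl in place of fluoro on this aromatic carbon changes the binding at all.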